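Working notes: compound 1 to compound 3

The compounds below may be only part of what the source reports. "The series", "measured", "known", "first", "only" and "open" are said of these compounds alone.

Measured so far:
- compound 1 `O=S(=O)(Nc1ccc2oc(-c3ccccc3)nc2c1)c1cccc(F)c1` — > 100000 nM
- compound 2 `O=S(=O)(Nc1ccc(-c2nc3cc(NS(=O)(=O)c4cccc(O)c4)ccc3o2)cc1)c1cccc(O)c1` — 17000 nM

Both were read in an assay on cells for inhibition of HSP60/HSP10 (Homo sapiens), with a stated time of 60 min; on this read-out lower numbers stand for stronger inhibition and higher numbers for weaker inhibition. For compound 1 this assay returns only a limit, > 100000 nM, and no number. Compound 1 thus sits at the limit of > 100000 nM in this assay, at which 1 of the 2 values shown sits. Compound 2 gives a measured number in this assay, 17000 nM. Going by the values given here, no pair of measured compounds differs in one place, so the two values show only that compound 2 yields a number where compound 1 does not.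

Compound 3 `COc1ccccc1S(=O)(=O)Nc1ccc2oc(-c3ccccc3)nc2c1` differs from compound 1 by 2-methoxyphenyl in place of 3-fluorophenyl on a sulfonyl sulfur. Among the compounds with values here, with no measured step to lean on, the expected change from compound 1 is none beyond the scatter, and the expected step is a number no higher from compound 1 to compound 3 (the limit leaves the size open). The estimate for compound 3 in this assay is 100000 nM, with an expected range from 30000 nM to 300000 nM, and a high chance that again only a limit is reported.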

Compound 3, half-maximal inhibitory concentration: > 100000 nM
Compound 3: no number, only a limit (the forecaster's own chance of this, stated with the estimate: 75%); the middle value lies on the limit itself.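

Compound 1 and compound 3 both return only a limit in this assay, so no step between them can be read: the limit of > 100000 nM in this assay, at which 2 of the 3 values shown sit.

Left open is whether 2-methoxyphenyl in place of 3-fluorophenyl on a sulfonyl sulfur changes inhibition at all.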